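The compounds below may be only part of what the source reports. "The series", "measured", "known", "first", "only" and "open" are said of these compounds alone.

Three compounds from this series carry numbers in a functional assay on NCI-H460 cells (Homo sapiens) for cytotoxicity, read by MTT assay, with a stated time of 48 h; on this read-out lower numbers stand for stronger inhibition and higher numbers for weaker inhibition. Compound 1 `CCCC[C@@H](C)C[C@@H](C)C(=O)N(C)[C@@H](CC(C)C)C(=O)N[C@H](C(=O)N(C)[C@H](C(=O)N1C[C@@H](O)C[C@H]1C(=O)N1C(=O)C=C[C@@H]1C)C(C)C)[C@@H](C)OC(=O)CC` gives 200 nM. Compound 2 `CCCC[C@@H](C)C[C@@H](C)C(=O)N(C)[C@@H](CC(C)C)C(=O)N[C@H](C(=O)N(C)[C@H](C(=O)N1C[C@@H](O)C[C@H]1C(=O)O)C(C)C)[C@@H](C)OC(C)=O` gives 510 nM, the highest of the three numbers. Compound 3 `CCCC[C@@H](C)C[C@@H](C)C(=O)N(C)[C@@H](CC(C)C)C(=O)N[C@H](C(=O)N(C)[C@H](C(=O)N1C[C@@H](O)C[C@H]1C(=O)N1C(=O)C=C[C@@H]1C)C(C)C)[C@@H](C)O` gives 75 nM, the lowest. Going by the values given here, the one single-point step recorded so far runs a 2.7-fold lower number from compound 1 to compound 3 (0.43 log units; beyond the scatter); it concerns the oxygen on the saturated carbon and not the carbonyl carbon that changes here.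

Compound 4 `CCCC[C@@H](C)C[C@@H](C)C(=O)N(C)[C@@H](CC(C)C)C(=O)N[C@H](C(=O)N(C)[C@H](C(=O)N1C[C@@H](O)C[C@H]1C(=O)N1C(=O)CC[C@@H]1C)C(C)C)[C@@H](C)OC(C)=O` has not yet been measured in this assay. It differs from compound 2 in one place: a group of 7 heavy atoms (5 carbon, 1 nitrogen, 1 oxygen; one five-membered non-aromatic ring with 1 hetero atom) in place of one oxygen atom, on a carbonyl carbon. Among the compounds with values here, no measured pair isolates this exact change. Compound 1 and compound 2 differ in two places at once, so their values only show that compound 1, which carries a ring on that carbonyl carbon, sits lower than compound 2, which carries the hydroxy there. The ring in compound 4 lacks the double bond that the rings of compound 1 and compound 3 contain, and the data hold nothing on that detail.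

Taken together, a lower number is expected for compound 4, with a step of about a 2.0-fold lower number from compound 2 to compound 4 (0.31 log units; beyond the scatter). Compound 4 is therefore estimated at 250 nM, within a range from 80 nM to 800 nM.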

Compound 4, half-maximal inhibitory concentration: 2800 nM
Estimate against measurement, compound 4: 11-fold (1.05 log units) below; the measured number lies above the stated range.
By their numbers in this assay, from the lowest: compound 3; then compound 1; then compound 2; then compound 4.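

In this assay, placing the group of 7 heavy atoms, with its one five-membered non-aromatic ring with 1 hetero atom, on the carbonyl carbon in place of the hydroxy gives a 5.5-fold higher number from compound 2 to compound 4 (0.74 log units; beyond the scatter). Going by these compounds alone, this is the first comparison that changes this place alone, and it shows that this ring without its double bond gives weaker inhibition than the hydroxy when the rest of the molecule stays the same, which the two-place difference between compound 1 and compound 2 could not show. Nothing available here gives a reason for this rise.

The compounds shown include no pair that sets the saturated ring of compound 4 against the ring with the double bond in compound 1 and compound 3 with all else equal, so the part played by that double bond remains open. Going by these compounds, it also remains open how other groups on this carbonyl carbon would read in this assay, for example a methoxy group or a simple amine, and whether any of them would give a lower number than the hydroxy.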